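This account rests on a few compounds, and the source may have more. Where it says the series, first, only, none or still open, it means among the compounds named here.

Measured compounds:
Compound 1 `Nc1ccccc1NC(=O)c1ccc(CSC(=S)N2CCN(Cc3ccccn3)CC2)cc1` gives 82.4%.
Compound 2 `Cc1ccc(N2CCN(C(=S)SCc3ccc(C(=O)Nc4ccccc4N)cc3)CC2)cc1` gives 26.4%.
Compound 3 `COC(=O)c1ccc2c(c1)CCN2C(=S)SCc1ccc(C(=O)Nc2ccccc2N)cc1` gives 79.2%.

In a functional assay on A-375 cells (Homo sapiens) for antiproliferative activity, read by CCK-8 assay, with a stated time of 72 h, tested at 8 uM (on this read-out lower numbers stand for a weaker effect and higher numbers for a stronger effect at the one concentration tested), compound 2 stands lowest of the three numbers, beyond the scatter from both others; compound 3 is its nearest neighbour and compound 1 its furthest, and those two lie within the scatter of each other.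

Compound 4 `Nc1ccccc1NC(=O)c1ccc(CSC(=S)N2CCN(Cc3ccccc3)CC2)cc1` differs from compound 2 in one place: benzyl in place of 4-methylphenyl on an amine nitrogen in a ring. Going by the values given here, the change reverses the kind of alteration seen in the only measured step that touches this position, a number 56 percentage points lower from compound 1 to compound 2 (beyond the scatter), where a directly attached aryl replaced a methylene-linked heteroaryl on the same ring nitrogen. Compound 4 returns to a methylene-linked aryl on that nitrogen, differing from compound 1 only in the ring of the pendant group. A large rise from compound 2 is therefore expected, with the estimate for compound 4 placed somewhat under the number of compound 1 because the supporting evidence is a single step, a number 56 percentage points lower from compound 1 to compound 2 (beyond the scatter). The expected step is a number 45.6 percentage points higher from compound 2 to compound 4 (beyond the scatter). Compound 4 is estimated at 72%, in the range 50% to 88%.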

Compound 4, a percentage reported as inhibition, at one concentration (the size of the read-out at that concentration, not a potency): 29.3%
Compound 4: the middle estimate sits 42.7 percentage points above what was measured; the whole stated range lies above it.
By their numbers in this assay, from the lowest: compounds 2 and 4 (each within the scatter of the next); then compounds 3 and 1 (each within the scatter of the next).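

In this assay, the change of link on the ring amine nitrogen makes no readable difference: with benzyl in place of 4-methylphenyl, the result is a number 2.9 percentage points higher from compound 2 to compound 4 (within the scatter). The pendant ring itself carries the large step, as phenyl in place of pyridin-2-yl on the saturated chain carbon gives a number 53.1 percentage points lower from compound 1 to compound 4 (beyond the scatter), so among compounds 1, 2 and 4 only compound 1, the one holding pyridin-2-yl, keeps the high number. No available evidence accounts for this difference.

The compounds shown leave open whether the placing of the ring nitrogen in the pendant group matters, which (pyridin-3-yl)methyl or (pyridin-4-yl)methyl on the same amine nitrogen would address. They also leave open whether a longer chain, such as 2-(pyridin-2-yl)ethyl, would hold the number of compound 1.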